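Replacing piperidin-1-yl with isopropoxy on the shared core

The compounds below may be only part of what the source reports. "The series", "measured", "known", "first", "only" and "open" are said of these compounds alone.

In a functional assay on the whole organism with Rattus norvegicus as the target (on this read-out lower numbers stand for an effect already at smaller amounts and higher numbers for an effect only at larger amounts of compound), compound 1 `CCOC(=O)C(=O)Nc1cccc(N(C)C)c1C#N` gives 0.2 mg/kg, while compound 2 `CCOC(=O)C(=O)Nc1cccc(N2CCCCC2)c1C#N` gives 2.2 mg/kg, the higher of the two numbers. Compound 3 `CCOC(=O)C(=O)Nc1cccc(OC(C)C)c1C#N` has not yet been measured. It differs from compound 2 at a single place: isopropoxy in place of piperidin-1-yl on an aromatic carbon. Thus isopropoxy stands in place of piperidin-1-yl on an aromatic carbon, ortho to a cyano group.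

Among the compounds with values here, only one measured step bears on this change. At the same place, piperidin-1-yl replacing dimethylamino gave an 11-fold higher number from compound 1 to compound 2 (1.04 log units; beyond the scatter), a large step beyond the scatter. Within the data shown here, compound 3 reverses the arrival of that ring, as its isopropoxy group has no ring, but it does not restore dimethylamino, and no measured compound carries isopropoxy. A return of the whole measured step therefore cannot be assumed. In this assay, a moderate step towards a lower number is expected, smaller than the measured one. The expected change is a 3.1-fold lower number from compound 2 to compound 3 (0.50 log units; beyond the scatter). For compound 3 the estimated dose is 0.7 mg/kg, with an expected range of 0.15 mg/kg to 3 mg/kg.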

Compound 3, dose for half-maximal effect: 2 mg/kg
Beside the measured number, compound 3's estimate is 2.9-fold (0.46 log units) below it; measured number inside the range.
By their numbers in this assay, from the lowest: compound 1; then compounds 3 and 2 (each within the scatter of the next).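

In this assay, isopropoxy in place of piperidin-1-yl gives a 1.1-fold lower number from compound 2 to compound 3 (0.04 log units; within the scatter) and so, at this place ortho to a cyano group, the loss of the ring and the change from nitrogen to oxygen on the aromatic carbon bring no difference that these numbers can show. Isopropoxy in place of dimethylamino gives a 10-fold higher number from compound 1 to compound 3 (1.00 log units; beyond the scatter) and thus, of the three groups, dimethylamino alone goes with the lower number, while the higher number is now seen with two different groups, one with a ring and one without, so it cannot be tied to the piperidine ring. Nothing measured here accounts for why dimethylamino stands apart from the other two groups.

Going by these compounds, what stays open is whether a close relative of dimethylamino, such as diethylamino or pyrrolidin-1-yl, would keep the number of compound 1 or fall in with compound 2 and compound 3, and where a methoxy group would stand. The compounds shown also leave open whether the same order of groups would hold with the ethyl ester replaced by a carboxylic acid.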